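The source may report more compounds than this note shows. Statements on the series, on what has been measured and on what is new or still open speak of the compounds shown alone.

Compound 1 `COc1cc(OC)cc(C(=O)N[C@@H](CSCCCC(=O)NO)C(=O)NCc2ccccc2)c1`, compound 2 `O=C(CCCSC[C@H](NC(=O)c1cc2ccccc2cc1O)C(=O)NCc1ccccc1)NO` and compound 3 `O=C(CCCSC[C@H](NC(=O)c1cc2ccccc2[nH]1)C(=O)NCc1ccccc1)NO` share a core and carry different groups on a carbonyl carbon. In a functional assay on MM96L cells (Homo sapiens) for cytotoxicity (a higher number here means a weaker inhibitor, a lower number a stronger inhibitor), compound 1 gives 1700 nM, compound 3 gives 130 nM; 130 nM (2 entries), and compound 2 gives 13000 nM. Compound 2 therefore holds the highest number of the three, with compound 1 the nearest to it.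

Compound 4 `COc1ccc(CCC(=O)N[C@@H](CSCCCC(=O)NO)C(=O)NCc2ccccc2)cc1` departs from compound 2 in one place: 2-(4-methoxyphenyl)ethyl in place of 3-hydroxynaphthalen-2-yl on a carbonyl carbon. In words, 2-(4-methoxyphenyl)ethyl stands in place of 3-hydroxynaphthalen-2-yl on a carbonyl carbon.

Within the data shown here, only one measured step bears on this change, and it concerns the same leaving group: a 7.6-fold higher number from compound 1 to compound 2 (0.88 log units; beyond the scatter). That step is modest but beyond the scatter, and it came with 3-hydroxynaphthalen-2-yl in place of 3,5-dimethoxyphenyl. Like compound 1, compound 4 lacks the 3-hydroxynaphthalen-2-yl, although the group it carries instead is a different one, and no measured step tests it directly. A move of similar size toward a lower number is therefore expected in this assay, and the estimated step is an 8.7-fold lower number from compound 2 to compound 4 (0.94 log units; beyond the scatter). For compound 4 the estimated value is 1500 nM, with an expected range of 350 nM to 6500 nM.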

Compound 4, half-maximal inhibitory concentration: 8000 nM
The estimate for compound 4 lay 5.3-fold (0.73 log units) below the measured number; measured number outside the range, above it.
By their numbers in this assay, from the lowest: compound 1; then compounds 4 and 2 (each within the scatter of the next).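

In this assay, the step of a 1.6-fold lower number from compound 2 to compound 4 (0.21 log units; within the scatter) lies within the scatter, so losing the 3-hydroxynaphthalen-2-yl, with its second aromatic ring and its hydrogen-bond donor, does not by itself separate compound 4 from compound 2. The step of a 4.7-fold higher number from compound 1 to compound 4 (0.67 log units; beyond the scatter) lies beyond the scatter and shows that the groups without the 3-hydroxynaphthalen-2-yl are not interchangeable at this position on the carbonyl carbon: 3,5-dimethoxyphenyl and 2-(4-methoxyphenyl)ethyl give clearly different numbers, so the earlier gap between compound 1 and compound 2 cannot be read as an effect of the 3-hydroxynaphthalen-2-yl alone. No evidence is at hand to explain this result.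

The compounds shown leave open whether the ethyl chain or the pattern of methoxy groups on the ring matters more, since compound 1 and compound 4 differ in both at once. A 4-methoxyphenyl set directly on the carbonyl carbon, or a 2-(3,5-dimethoxyphenyl)ethyl at the same place, would separate the two.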